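The source may hold more compounds than are shown below. What is called first, only, known or untested is meant among the compounds shown, and "the series" means these compounds.

Of the compounds shown here, two have numbers so far. Compound 1 `O=C(Nc1ccccn1)c1ccccc1-c1ccccc1` in an in vitro functional assay on HEK ts201 cells for antagonist activity at Neuronal acetylcholine receptor; alpha4/beta2 (Homo sapiens), read by fluorescence and calcium flux (a lower number here means a stronger inhibitor, a higher number a weaker inhibitor), gives 13600 nM. Compound 2 `CC1CC(=O)N(c2ccccc2C(=O)OCC2CCCN(CCCCCOc3ccc(Cl)c(Cl)c3)C2)C1=O` in this assay gives 17400 nM, the higher of the two numbers, but its gap to compound 1 sits within the scatter of repeated runs, so the two stand together as weak inhibitors and no order between them can be read.

The next compound on the series is compound 3 `CC1CC(=O)N(c2ccccc2C(=O)OCC2CCCN(CCCCCCc3ccccc3)C2)C1=O`, which differs from compound 2 in one place: benzyl in place of 3,4-dichlorophenoxy on a saturated chain carbon, five bonds along the chain from an amine nitrogen in a ring. The shared core, the ring amine and the chain are kept; only the aromatic end of the chain changes.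

Within the data shown here, no step between two measured compounds touches this change, so nothing in hand says which way it moves the number. With both measured compounds at the weak end of the scale, the step from compound 2 to compound 3 is expected to fall within the scatter, as a 1.1-fold higher number from compound 2 to compound 3 (0.06 log units; within the scatter). Compound 3 is estimated to give 20000 nM in this assay, with a range of 7000 nM to 60000 nM.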

Compound 3, half-maximal inhibitory concentration: 29500 nM
Beside the measured number, compound 3's estimate is 1.5-fold (0.17 log units) below it; the measured number falls inside the stated range.
By their numbers in this assay, from the lowest: compounds 1, 2 and 3 (each within the scatter of the next, the first and the last beyond it).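

In this assay, among these compounds, the first change at this position, benzyl in place of 3,4-dichlorophenoxy on a saturated chain carbon, five bonds along the chain from an amine nitrogen in a ring, reads as a 1.7-fold higher number from compound 2 to compound 3 (0.23 log units; within the scatter) and so cannot be told apart from repeat scatter. The step takes away the ether oxygen and both chlorine atoms in one move, while a six-membered aromatic ring of carbon only stays at the end of the chain. Among the compounds shown here, at this position, then, compound 2 and compound 3 stand together as weak inhibitors, and the series so far shows no sensitivity to this swap, though one step at the weak end of the scale is thin ground, and no other data bear on it.

The step changes the oxygen and the chlorines together, so a plain phenoxy or a 3,4-dichlorobenzyl group on the same chain would be needed to read each part alone. Also open, from the compounds shown here alone, is whether anything at this chain end, such as a carboxylic acid or an amine, or a shorter chain, moves the number out of the weak range.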